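Moving a Fluorine Along the Carboxyphenyl Group

The source may report more compounds than this note shows. Statements on the series, on what has been measured and on what is new or still open speak of the compounds shown alone.

Of the compounds shown here, three sharing one core have been measured in an assay for positive allosteric modulation of metabotropic glutamate receptor 3 (Rattus norvegicus); a higher number here means that more compound is needed for the effect, a lower number that less compound is needed. Compound 1 `Cc1c(OC[C@@H](C)COc2ccc(Cl)c(C(=O)O)c2)ccc(C(=O)CC(C)(C)C)c1O` gives 2200 nM. Compound 2 `Cc1cc(C(=O)O)ccc1OC[C@H](C)COc1ccc(C(=O)CC(C)(C)C)c(O)c1C` gives 1520 nM, and compound 3 `Cc1c(OC[C@@H](C)COc2ccc(C(=O)O)cc2F)ccc(C(=O)CC(C)(C)C)c1O` gives 1300 nM. Compound 3 has the lowest of the three numbers, yet each step toward it stays within the scatter: a 1.7-fold lower number from compound 1 to compound 3 (0.23 log units; within the scatter) and a 1.2-fold lower number from compound 2 to compound 3 (0.07 log units; within the scatter). None of the three can be set apart from the others on these data.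

Compound 4 `Cc1c(OC[C@@H](C)COc2ccc(C(=O)O)c(F)c2)ccc(C(=O)CC(C)(C)C)c1O` has not yet been measured in this assay. It differs from compound 3 in one place: 4-carboxy-3-fluorophenyl in place of 4-carboxy-2-fluorophenyl on an oxygen on a saturated carbon. The two have the same atoms, joined differently.

For the measured compounds named here, no measured step moves a fluorine from one carbon of the carboxyphenyl ring to another. The nearest guides are the exchanges of the whole aryl group, a 1.4-fold lower number from compound 1 to compound 2 (0.16 log units; within the scatter) and a 1.7-fold lower number from compound 1 to compound 3 (0.23 log units; within the scatter), and the smaller swap a 1.2-fold lower number from compound 2 to compound 3 (0.07 log units; within the scatter); every one of them stayed within the scatter. On that basis no step beyond the scatter is expected in this assay, in either direction. Compound 4 is therefore expected to give about 1400 nM, with a range from 600 nM to 3500 nM. This corresponds to an expected step of a 1.1-fold higher number from compound 3 to compound 4 (0.03 log units; within the scatter).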

Compound 4, half-maximal effective concentration: 1090 nM
Beside the measured number, compound 4's estimate is 1.3-fold (0.11 log units) above it; the measured number falls inside the stated range.
By their numbers in this assay, from the lowest: compounds 4, 3, 2 and 1 (each within the scatter of the next).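

In this assay, for the compounds shown here, 4-carboxy-3-fluorophenyl in place of 4-carboxy-2-fluorophenyl on an oxygen on a saturated carbon gives the first direct comparison of two fluorine placements on the carboxyphenyl group: a 1.2-fold lower number from compound 3 to compound 4 (0.08 log units; within the scatter), so these two isomers cannot be told apart. The exchanges of the whole aryl group read the same way, with a 1.4-fold lower number from compound 2 to compound 4 (0.14 log units; within the scatter) and a 2.0-fold lower number from compound 1 to compound 4 (0.30 log units; within the scatter), which means that all four aryl groups shown remain indistinguishable in this measurement, and moving the fluorine adds no step beyond the scatter to the earlier picture. Nothing available bears on the reason for this result.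

The compounds shown leave open whether any other group on this aryl ring would produce a step beyond the scatter, such as a nitrile or a methoxy group in place of the fluorine, or an amide in place of the carboxylic acid. They also leave open whether a longer chain joining the carboxyphenyl group to the rest of the shared core would separate these fluorine isomers.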